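Methyl in Place of Methoxy: From Compound 2 to Compound 4

The source may report more compounds than this note shows. Statements on the series, on what has been measured and on what is new or still open speak of the compounds shown alone.

In a functional assay on DU-145 cells (Homo sapiens) for antiproliferative activity, read by MTT assay, with a stated time of 24 h (on this read-out higher numbers stand for weaker inhibition and lower numbers for stronger inhibition), compound 2 `COc1ccc(/C=C/C(=O)c2cc(-c3ccc(OC)c(OC)c3)n3nc(-c4ccccc4)cc3n2)cc1` gives 14900 nM. Compound 3 `COc1cc(-c2cc(C(=O)/C=C/c3ccc(Cl)cc3)nc3cc(-c4ccccc4)nn23)cc(OC)c1OC` gives 19500 nM and compound 1 `COc1ccc(C(=O)/C=C/c2cc(-c3cc(OC)c(OC)c(OC)c3)n3nc(-c4ccccc4)cc3n2)cc1` gives 25200 nM; neither is separated from compound 2 beyond the scatter, so the three stand together. Compound 4 `COc1ccc(-c2cc(C(=O)/C=C/c3ccc(C)cc3)nc3cc(-c4ccccc4)nn23)cc1OC` differs from compound 2 by methyl in place of methoxy on an aromatic carbon. Among the compounds with values here, no measured pair shows this exchange. Within the data shown here, the only single-place step among the measured compounds, a 1.3-fold lower number from compound 1 to compound 3 (0.11 log units; within the scatter), touches a different part of the molecule and stays within the scatter. With nothing pointing in either direction, the step from compound 2 to compound 4 is expected to be small, a 1.0-fold higher number from compound 2 to compound 4 (0.00 log units; within the scatter). Compound 4 is therefore estimated at 15000 nM, in a range from 6000 nM to 40000 nM.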

Compound 4, half-maximal inhibitory concentration: 19500 nM
Beside the measured number, compound 4's estimate is 1.3-fold (0.11 log units) below it, and the stated range covers the measured number.
By their numbers in this assay, from the lowest: compounds 2, 3, 4 and 1 (each within the scatter of the next).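

In this assay, the change from 4-methoxyphenyl to 4-methylphenyl gives a 1.3-fold higher number from compound 2 to compound 4 (0.12 log units; within the scatter), a direct reading of this exchange at this position. Methyl carries no hydrogen-bond acceptor where methoxy carries one, yet the step stays within the scatter. No evidence is available that bears on this result.

From the compounds shown here alone, whether an amine, a carboxylic acid or a longer chain at this place would give a step beyond the scatter remains open. The compounds shown also leave open whether this exchange would behave alike on other cores.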